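The source may report more compounds than this note shows. Statements on the series, on what has been measured and on what is new or still open speak of the compounds shown alone.

Compound 1 `CSc1nc(-c2ccco2)c(C#N)c(=O)n1C` gives 108 ug/mL in a functional assay, with a stated time of 150 min; a higher number here means a weaker inhibitor, a lower number a stronger inhibitor. Compound 2 `CSc1nc(-c2cccs2)c(C#N)c(=O)n1C` gives 87 ug/mL in this assay. Compound 3 `CCOC(=O)c1cnn(-c2nc(-c3ccco3)c(C#N)c(=O)n2C)c1N` gives 108 ug/mL in this assay.

One structural change occurs twice in this set. Between compound 1 and compound 2 it is thiophen-2-yl in place of furan-2-yl on an aromatic carbon, and it produced a 1.2-fold lower number from compound 1 to compound 2 (0.09 log units; within the scatter). How the core of compound 3 differs from the core of compound 1 is not broken down here. Compound 4 `CCOC(=O)c1cnn(-c2nc(-c3cccs3)c(C#N)c(=O)n2C)c1N` carries the same kind of change made on compound 3: thiophen-2-yl in place of furan-2-yl on an aromatic carbon. The surroundings are not word for word the same: in compound 1 the place is meta to a methylsulfanyl group (2 heavy atoms), whereas in compound 3 it is meta to a large group. Compound 4 is expected to show a 1.2-fold lower number from compound 3 to compound 4 (0.08 log units; within the scatter), because a 1.2-fold lower number from compound 1 to compound 2 (0.09 log units; within the scatter) was seen with the matching change. Compound 4 is thus estimated to give 90 ug/mL in this assay.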

Compound 4, half-maximal inhibitory concentration: 98 ug/mL
Compound 4: middle estimate off by 1.1-fold (0.04 log units), on the low side, and the stated range covers the measured number.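

In this assay, thiophen-2-yl in place of furan-2-yl on compound 3 gave a 1.1-fold lower number from compound 3 to compound 4 (0.04 log units; within the scatter), and this step agrees with the one seen on the core of compound 1: the same change on two cores in this assay, a 1.2-fold lower number (0.09 log units; within the scatter) from compound 1 to compound 2 and a 1.1-fold lower number (0.04 log units; within the scatter) from compound 3 to compound 4, 1.1-fold (0.05 log units) apart, within the scatter of two such steps. Across these two cores, then, the change carried over as a step too small to separate from the scatter. It does not show that the change truly shifts the number in either direction, and two pairs cannot speak for other cores in the series.

The compounds shown leave open whether a group other than these two rings, such as phenyl or an amine, would shift the number beyond the scatter at this place. Also open, as far as these compounds go, is how the change behaves where a carboxylic acid stands in place of the ethyl ester of compound 3.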